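The source may hold more compounds than are shown below. What is called first, only, known or untested is meant among the compounds shown, and "the series" means these compounds.

Compound 1 `Cc1ccc(S(=O)(=O)N[C@@H](CC(=O)NC(C)(C)C)C(=O)NCCNC(=O)c2cc(C)ccc2F)cc1`: in an ADME assay on Karpas-1106P cells (Homo sapiens) for cytotoxicity (a higher number here means that more compound is needed for the effect, a lower number that less compound is needed), compound 1 gives > 11100 nM, which is a limit of the assay rather than a number.
Compound 2 `Cc1ccc(S(=O)(=O)N[C@@H](CC(=O)NC(C)(C)C)C(=O)NCCNC(=O)c2c(O)cccc2F)cc1`: in this assay compound 2 gives > 11100 nM, also only a limit.

Compound 1 therefore stands at a limit, and every value shown sits there (the limit of > 11100 nM in this assay, at which 2 of the 2 values shown sit). Compound 3 `Cc1ccc(S(=O)(=O)N[C@@H](CC(=O)NC(C)(C)C)C(=O)NCCNC(=O)c2cccc(C(F)(F)F)c2)cc1` differs from compound 1 in one place: 3-(trifluoromethyl)phenyl in place of 2-fluoro-5-methylphenyl on a carbonyl carbon. Among the compounds with values here, the one measured step that bears on this, a step that the two limits leave unreadable from compound 1 to compound 2, also changes the group on the carbonyl carbon, but its size cannot be read, so no step beyond the scatter in either direction is expected. Compound 3 is expected to sit near the same limit, estimated at 15000 nM (range 5000 nM to 50000 nM). That amounts to an expected step that the limit leaves unreadable from compound 1 to compound 3.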

Compound 3, half-maximal effective concentration: > 11100 nM
Compound 3 gave a limit, no number; the forecaster's own chance of this, stated with the estimate: 80%; the middle value lies beyond the limit too.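

Within the data shown here, compound 1, compound 2 and compound 3 all stop at a limit, so no step among them can be read: the limit of > 11100 nM in this assay, at which 3 of the 3 values shown sit.
What the compounds shown leave open is how much of any of them this assay would need for the effect, and whether the group on the carbonyl carbon changes that amount.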